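The compounds below may be only part of what the source reports. "The series", "measured", "known", "first", "only" and "open" are said of these compounds alone.

In a functional assay on HT-29 cells (Homo sapiens) for inhibition, with a stated time of 72 h (on this read-out lower numbers stand for stronger inhibition and higher numbers for weaker inhibition), compound 1 `COc1cc(C(=O)c2ccc3[nH]ccc3c2)cc(OC)c1OC` gives 100 nM, compound 2 `CCCn1ccc2cc(C(=O)c3cc(OC)c(OC)c(OC)c3)ccc21` gives 1800 nM and compound 3 `COc1cc(C(=O)c2ccc3c(ccn3C(C)C)c2)cc(OC)c1OC` gives 1200 nM. Compound 3 thus sits level with compound 2 and far from compound 1. Both alkyl groups on the aromatic nitrogen cost much against hydrogen: an 18-fold higher number from compound 1 to compound 2 (1.26 log units; beyond the scatter), and a 12-fold higher number from compound 1 to compound 3 (1.08 log units; beyond the scatter). Exchanging one for the other does little: a 1.5-fold lower number from compound 2 to compound 3 (0.18 log units; within the scatter). Compound 4 `COc1cc(C(=O)c2ccc3c(ccn3CC(=O)O)c2)cc(OC)c1OC` has carboxymethyl in place of isopropyl on an aromatic nitrogen. For the measured compounds named here, no measured compound carries carboxymethyl, so these steps guide the expectation only loosely. A moderate step towards a higher number is expected in this assay. The expected change is a 2.5-fold higher number from compound 3 to compound 4 (0.40 log units; beyond the scatter). The estimate for compound 4 is 3000 nM, with a range of 800 nM to 15000 nM.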

Compound 4, half-maximal inhibitory concentration: 460 nM
Beside the measured number, compound 4's estimate is 6.5-fold (0.81 log units) above it; the whole stated range lies above it.
By their numbers in this assay, from the lowest: compound 1; then compound 4; then compounds 3 and 2 (each within the scatter of the next).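

In this assay substitution on the aromatic nitrogen does not carry one uniform cost, since carboxymethyl improves on both alkyl groups (a 2.6-fold lower number from compound 3 to compound 4 (0.42 log units; beyond the scatter); a 3.9-fold lower number from compound 2 to compound 4 (0.59 log units; beyond the scatter)). The gain remains partial, and hydrogen on this nitrogen still gives the lower number (a 4.6-fold higher number from compound 1 to compound 4 (0.66 log units; beyond the scatter)). Nothing available explains this difference between carboxymethyl and the alkyl groups. The compounds shown leave open whether the carboxylic acid itself is needed for this gain, or whether its methyl ester or primary amide would match it. An amine on a chain at this nitrogen also remains untested in the compounds shown.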